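Oxan-4-yl returns on the chain: expectation for compound 3

The compounds below may be only part of what the source reports. "The series", "measured", "known", "first", "only" and "open" are said of these compounds alone.

Measured so far in an ADME assay on the whole organism for pharmacokinetics, with Rattus norvegicus as the target, at a dose of 5 mg/kg by the oral route; on this read-out lower numbers stand for lower exposure and higher numbers for higher exposure at the dose given
compound 1 `CC(C)(O)c1ccc(-c2cnc3c(n2)N(CCC2CCOCC2)C(=O)CN3)cn1` gives 1700 nM
compound 2 `COCCN1C(=O)CNc2ncc(-c3ccc(C(C)(C)O)nc3)nc21` gives 5600 nM

Compound 2 holds the higher of the two numbers, and compound 1 lies lower by a margin beyond the scatter. The next compound is compound 3 `CC(C)(O)c1ccc(-c2cnc3c(n2)N(CC2CCOCC2)C(=O)CN3)cn1`, and the change from compound 2 is this: oxan-4-yl in place of methoxymethyl on a saturated chain carbon bound to an amide-type nitrogen in a ring. In words, it is oxan-4-yl in place of methoxymethyl on a saturated chain carbon bound to an amide-type nitrogen in a ring.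

Going by the values given here, only one measured step bears on this change: a 3.3-fold higher number from compound 1 to compound 2 (0.52 log units; beyond the scatter) with methoxy in place of oxan-4-yl on a saturated chain carbon, two bonds along the chain from an amide-type nitrogen in a ring. Among the compounds with values here, compound 3 carries oxan-4-yl as compound 1 does, but at a different place on the chain, and no measured compound shows that placement. Read in reverse, the modest step of a 3.3-fold higher number from compound 1 to compound 2 (0.52 log units; beyond the scatter) leads to the expectation of a step of similar size toward a lower number in this assay. The estimated step is a 2.5-fold lower number from compound 2 to compound 3 (0.41 log units; beyond the scatter) on this single precedent. For compound 3 the estimated value is 2200 nM within an expected range of 800 nM to 5500 nM at the same oral dose.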

Compound 3, maximal plasma concentration: 1600 nM
Compound 3: middle estimate off by 1.4-fold (0.14 log units), on the high side, and the stated range covers the measured number.
By their numbers in this assay, from the lowest: compounds 3 and 1 (each within the scatter of the next); then compound 2.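

In this assay, going from 2-methoxyethyl to (oxan-4-yl)methyl gives a second step beyond the scatter (a 3.5-fold lower number from compound 2 to compound 3 (0.54 log units; beyond the scatter)), so compound 2 now stands apart from both compounds that carry oxan-4-yl, not from compound 1 alone. Shifting oxan-4-yl along the chain does not separate the two compounds that carry it (a 1.1-fold lower number from compound 1 to compound 3 (0.03 log units; within the scatter)), so within this set the read-out follows which group the chain carries rather than where oxan-4-yl sits on it, a pattern that rests on these three compounds only and that none of them goes against. No measurement at hand accounts for the gap between compound 2 and the two compounds carrying oxan-4-yl.

The compounds shown leave open whether the higher number of compound 2 belongs to the methoxy group itself or simply to a chain without a ring, a question that a 2-hydroxyethyl chain, a plain propyl chain or a 2-(dimethylamino)ethyl chain at this place would bear on. They also leave open whether the same order would hold at another dose or by another route.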